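Meta-chloro on the benzoate of an aryl ester series

The source may report more compounds than this note shows. Statements on the series, on what has been measured and on what is new or still open speak of the compounds shown alone.

Four esters of one shared aromatic core are compared. Compound 1 `CC1=CC[C@H](C(C)C)c2cc(C)c(OC(=O)c3ccc(C)cc3)cc21` carries a 4-methylphenyl group on its carbonyl carbon, compound 2 `CC1=CC[C@H](C(C)C)c2cc(C)c(OC(=O)Nc3ccccc3)cc21` an anilino group there, and compound 3 `CC1=CC[C@H](C(C)C)c2cc(C)c(OC(=O)c3ccccc3)cc21` a plain phenyl group. In a functional assay on K562 cells (Homo sapiens) for antiproliferative activity, read by sulforhodamine B assay, with a stated time of 48 h, tested at 50 uM (on this read-out higher numbers stand for more inhibition at the one concentration tested (going by the name of the read-out) and lower numbers for less inhibition), compound 1 gives 100%, and in the same assay compound 2 gives 92.6%; the step of a number 7.4 percentage points lower from compound 1 to compound 2 (within the scatter) lies within the scatter. Compound 3 stands apart from both, as it was reported in this assay only as "not active" (no number reported), with no number attached, so the size of its inhibition cannot be placed on the scale of the other two.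

Compound 4 `CC1=CC[C@H](C(C)C)c2cc(C)c(OC(=O)c3cccc(Cl)c3)cc21` has not yet been measured. It differs from compound 3 in one place: chloro in place of hydrogen on an aromatic carbon, on an aromatic carbon that is meta to a large group. Within the data shown here, none of the measured steps involve this change, so no step bears directly on it. Among the measured compounds shown here, what the numbers show is only that compound 1 and compound 2, each with a substituted or nitrogen-linked aryl group, gave high inhibition, while compound 3 with the bare phenyl gave none reported. For compound 4 in this assay the inhibition is therefore estimated at 45%, with a wide range from 0% to 100%.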

Compound 4, a percentage reported as inhibition, at one concentration (the size of the read-out at that concentration, not a potency): "not active" (no number reported)
For compound 4 the study gives words and no number; no gap can be computed for the estimate.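

Compound 3 and compound 4 were both reported in this assay only as "not active", without a number, so no step can be read between them. Nothing shown bears on this result. The compounds shown leave open whether phenyl and 3-chlorophenyl differ at all in the inhibition they give.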